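Replacing the Sulfonamide Arm with Cyclopropyl on the Triazole

The source may report more compounds than this note shows. Statements on the series, on what has been measured and on what is new or still open speak of the compounds shown alone.

In a functional assay on CFPAC-1 cells (Homo sapiens) for antiproliferative activity, read by MTT assay, with a stated time of 72 h (on this read-out higher numbers stand for weaker inhibition and lower numbers for stronger inhibition), compound 3 `O=C1O[C@H]([C@@H](O)Cn2cc(CNS(=O)(=O)c3ccc(F)cc3)nn2)C(OCc2ccccc2)=C1OCc1ccccc1` gives 34700 nM, the lowest of the two numbers obtained. Compound 2 `O=C1O[C@H]([C@@H](O)Cn2cc(CNS(=O)(=O)c3ccc(Cl)cc3F)nn2)C(OCc2ccccc2)=C1OCc1ccccc1` gives 58200 nM, and the step of a 1.7-fold lower number from compound 2 to compound 3 (0.22 log units; within the scatter) lies within the scatter. For compound 1 `COc1ccc(-c2cn(C/C=C3\OC(=O)C(OCc4ccccc4)=C3OCc3ccccc3)nn2)cc1` the this assay reports a limit, > 100000 nM, as recorded in the limit of > 100000 nM in this assay, at which 1 of the 3 values shown sits. Compound 4 `O=C1O[C@H]([C@@H](O)Cn2cc(C3CC3)nn2)C(OCc2ccccc2)=C1OCc1ccccc1` differs from compound 3 by cyclopropyl in place of (((4-fluorophenyl)sulfonyl)amino)methyl on an aromatic carbon. For the measured compounds named here, the single measured step exchanges aryl groups on the sulfonyl sulfur and keeps the rest of that arm, so it does not bear on removing it, and no other pair differs at this carbon alone. The step of a 2.3-fold higher number from compound 3 to compound 4 (0.36 log units; beyond the scatter) is therefore expected to run toward a higher number, with little confidence. Compound 4 is estimated at 80000 nM, within 25000 nM to 300000 nM.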

Compound 4, half-maximal inhibitory concentration: 47700 nM
Compound 4: middle estimate off by 1.7-fold (0.22 log units), on the high side; the measured number falls inside the stated range.
By their numbers in this assay, from the lowest: compounds 3, 4 and 2 (each within the scatter of the next). At a limit, above all of these: compound 1.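

Exchanging the (((4-fluorophenyl)sulfonyl)amino)methyl arm for cyclopropyl on this aromatic carbon gives, in this assay, a 1.4-fold higher number from compound 3 to compound 4 (0.14 log units; within the scatter). The earlier step changed only the aryl group on the sulfonyl sulfur, whereas this one shows that the arm as a whole, with its 12 heavy atoms, can give way to 3 carbons with the number staying within the scatter. Nothing shown here accounts for this outcome. On these data alone, whether an aminomethyl group, a carboxylic acid or a longer alkyl chain on this carbon would move the number beyond the scatter remains open.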